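This account rests on a few compounds, and the source may have more. Where it says the series, first, only, none or still open, it means among the compounds named here.

Among the measured compounds shown here, compound 2 `CCCc1cc(N)c2cc(NC(=O)/C=C/c3ccc(C(C)C)cc3)ccc2n1` gives 2.9 nM in an assay on isolated protein for displacement of a labelled ligand from melanin-concentrating hormone receptor 1 (Homo sapiens) (on this read-out lower numbers stand for stronger inhibition and higher numbers for weaker inhibition), the higher of the two numbers measured so far. Compound 1 `CCCc1cc(N)c2cc(NC(=O)/C=C/c3ccc(CC)cc3)ccc2n1` gives 1.4 nM. For the measured compounds named here, the step of a 2.1-fold higher number from compound 1 to compound 2 (0.32 log units; beyond the scatter) is the only measured change, and it concerns a small alkyl group. Compound 3 `CCCc1cc(N)c2cc(NC(=O)/C=C/c3ccc(O)cc3)ccc2n1` differs from compound 2 by hydroxy in place of isopropyl on an aromatic carbon. Going by the values given here, no measured compound carries a hydroxy group, so that one modest alkyl step is only a loose guide, and the estimate must be wide. For compound 3 a step of a 2.1-fold higher number from compound 2 to compound 3 (0.32 log units; beyond the scatter) is expected, giving an estimated 6 nM with a range from 1.2 nM to 30 nM.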

Compound 3, half-maximal inhibitory concentration: 1100 nM
For compound 3 the middle estimate is 180-fold (2.26 log units) below the measured one; measured number outside the range, above it.
By their numbers in this assay, from the lowest: compound 1; then compound 2; then compound 3.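

In this assay hydroxy in place of an alkyl group on this aromatic carbon brings a 380-fold higher number from compound 2 to compound 3 (2.58 log units; beyond the scatter) and a 790-fold higher number from compound 1 to compound 3 (2.90 log units; beyond the scatter) as well, so the position that took ethyl and isopropyl with only a modest shift is far from indifferent to every group. Nothing available here explains this drop. The compounds shown leave open whether the loss belongs to hydroxy alone or extends to methoxy, an amine or a carboxylic acid at this place. They also leave open how a longer alkyl chain would fare here.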